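The compounds below may be only part of what the source reports. "The series", "measured", "known", "first", "only" and "open" are said of these compounds alone.

Measured so far in an ADME assay on Huh-7 cells (Homo sapiens) for cytotoxicity; on this read-out higher numbers stand for lower toxicity in this test and lower numbers for higher toxicity in this test:

compound 1 `NC(=S)N1CCc2c(OCCCCCOc3ccc(Cl)cc3)cccc21` — > 50000 nM
compound 2 `O=C(NC(=S)N1CCc2ccc(OCc3ccccc3)cc21)c1ccccc1` — 43800 nM
compound 3 `N#Cc1cccc(C(=O)NC(=S)N2CCc3c(OCCCCCOc4ccc(Cl)cc4)cccc32)c1` — 9750 nM

Compound 1 stands at a limit of this assay, not at a number; the value given for compound 1 is the limit of > 50000 nM in this assay, at which 1 of the 3 values shown sits. Compound 2 and compound 3 both give numbers, and compound 3 carries the same core as compound 1 with an acyl group on the thiourea nitrogen. Among the measured compounds shown here, the one step measured is an at least 5.1-fold lower number from compound 1 to compound 3 (0.70 log units; beyond the scatter), a move toward higher toxicity from a starting point that is itself only a limit, so its true size is open upward.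

Compound 4 `COc1ccc(C(=O)NC(=S)N2CCc3c(OCCCCCOc4ccc(Cl)cc4)cccc32)cc1` is the next analogue of compound 1 to be tested. It differs from compound 1 as follows: (4-methoxyphenyl)carbonyl in place of hydrogen on an amide-type nitrogen. For the measured compounds named here, this is the same kind of change as from compound 1 to compound 3, with a (4-methoxyphenyl)carbonyl entering instead of a (3-cyanophenyl)carbonyl; the difference between those two groups cannot be judged from the numbers available, and compound 2, which carries a different core substituent, gives no step to either.

Going by the values given here, on the strength of the one comparable step, the expected step for compound 4 is an at least 3.3-fold lower number from compound 1 to compound 4 (0.52 log units; beyond the scatter). The estimate for compound 4 in this assay is 15000 nM, with a range from 5000 nM to 45000 nM.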

Compound 4, half-maximal cytotoxic concentration: 34400 nM
Compound 4: the middle estimate sits 2.3-fold (0.36 log units) below what was measured; measured number inside the range.
By their numbers in this assay, from the lowest: compound 3; then compounds 4 and 2 (each within the scatter of the next). At a limit, above all of these: compound 1.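

In this assay, the aryl part of the acyl group on the amide-type nitrogen now makes a difference: 4-methoxyphenyl in place of 3-cyanophenyl on the carbonyl carbon gives a 3.5-fold higher number from compound 3 to compound 4 (0.55 log units; beyond the scatter), a step with a measured number at both ends. Placing an acyl group on this nitrogen therefore does not in itself bring the shift seen with compound 3: the new step is an at least 1.4-fold lower number from compound 1 to compound 4 (0.16 log units; that floor lies within the scatter), so no move toward higher toxicity in this test is established for compound 4. This step remains a floor, with its true size open, because compound 1 gives no number, only a limit: the limit of > 50000 nM in this assay, at which 1 of the 4 values shown sits.

Still open, on these data alone, is whether the gap follows the nitrile and methoxy groups themselves or their places on the ring, which 4-cyanophenyl and 3-methoxyphenyl on the core of compound 1 would separate. Among the compounds shown here, also open is where plain phenylcarbonyl or acetyl on that core would fall, since compound 2 carries phenylcarbonyl on a different core and gives no step to either compound.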